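From fluoro to cyano on a shared core

The compounds below may be only part of what the source reports. "The series", "measured", "known", "first", "only" and "open" are said of these compounds alone.

compound 1 `CC(=O)N[C@@H]1CCC[C@H](C(=O)Nc2cc(-c3cnn4c3CCCC4)c(F)cn2)C1`: 2.9
compound 2 `CC(=O)N[C@@H]1CCC[C@H](C(=O)Nc2cc(-c3cnn4c3CC(C)(C)C4)ccn2)C1`: 2.8
compound 3 `CC(=O)N[C@@H]1CCC[C@H](C(=O)Nc2cc(-c3cnn4c3CC(C)(C)C4)c(F)cn2)C1`: 3.3

All three compounds were measured in a physicochemical assay for lipophilicity, using the shake flask method, measured as octanol-water partition, at pH 7.4; a lower number here means a more polar compound, a higher number a more lipophilic compound. Compound 3 gives the highest number of the three, 3.3. The two steps leading to it are both modest but beyond the scatter: a number 0.40 log units higher from compound 1 to compound 3 (beyond the scatter) and a number 0.50 log units higher from compound 2 to compound 3 (beyond the scatter).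

The next compound, compound 4 `CC(=O)N[C@@H]1CCC[C@H](C(=O)Nc2cc(-c3cnn4c3CC(C)(C)C4)c(C#N)cn2)C1`, keeps all of compound 3 except for one group: cyano in place of fluoro on an aromatic carbon, (cyano in place of fluoro on an aromatic carbon).

The step of a number 0.40 log units higher from compound 1 to compound 3 (beyond the scatter) changes a different part of the molecule, so it offers little guidance here. The more useful step is a number 0.50 log units higher from compound 2 to compound 3 (beyond the scatter), which puts fluoro in place of hydrogen on the same aromatic carbon. Taking fluoro away therefore points back towards compound 2 at 2.8. Among the measured compounds shown here, none of the measured compounds carries cyano, so its own effect on the number is unknown and the range must stay wide.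

In this assay, a modest fall is expected, and the estimated step is a number 0.40 log units lower from compound 3 to compound 4 (beyond the scatter). Compound 4 is expected at 2.9, with an estimated range from 2.5 to 3.3.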

Compound 4, distribution coefficient: 3.2
Estimate against measurement, compound 4: 0.30 log units below; measured number inside the range.
By their numbers in this assay, from the lowest: compounds 2, 1, 4 and 3 (each within the scatter of the next, the first and the last beyond it).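

In this assay putting cyano in place of fluoro on this aromatic carbon gives a number 0.10 log units lower from compound 3 to compound 4 (within the scatter) and so the two groups cannot be told apart at this position, even though cyano brings 1 hydrogen-bond acceptor where fluoro has 0. Measured against the plain hydrogen of compound 2, cyano gives a number 0.40 log units higher from compound 2 to compound 4 (beyond the scatter) and fluoro gives a number 0.50 log units higher from compound 2 to compound 3 (beyond the scatter) and thus, in these compounds, both groups raise the number beyond the scatter, so the earlier fluoro step turns out not to be specific to fluoro. Nothing measured here explains why two such different groups give numbers this close and the match can only be recorded as it stands.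

Where a chlorine, a methoxy group, an amine or a carboxylic acid on the same aromatic carbon would fall in this assay remains open. Among the compounds shown here, it is also open whether cyano and fluoro would again match on the core of compound 1, since cyano appears here on only one core.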